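Removing the Protecting Group from Compound 3

A few compounds are considered here, and "the series" means these few. Any claim that something is new, unique, unknown or untested is made for them only; others in the source may bear on it.

Three compounds have been measured:
Compound 1, `O=C(CN1CCNCC1)N1CCC(NS(=O)(=O)c2cc(S(=O)(=O)c3ccccc3)ccc2C(F)(F)F)CC1`: in an assay on isolated protein for binding affinity to secreted frizzled-related protein 1 (Homo sapiens), read by fluorescence (a lower number here means a stronger inhibitor, a higher number a weaker inhibitor), compound 1 gives 140 nM.
Compound 2, `O=C(Cn1ccnc1)N1CCC(NS(=O)(=O)c2cc(S(=O)(=O)c3ccccc3)ccc2C(F)(F)F)CC1`: in this assay compound 2 gives 30 nM.
Compound 3, `CC(C)(C)OC(=O)N1C(=O)CC[C@H]1C(=O)N1CCC(NS(=O)(=O)c2cc(S(=O)(=O)c3ccccc3)ccc2C(F)(F)F)CC1`: in this assay compound 3 gives 130 nM.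

Compound 3 stands second highest of the three numbers. Its value and that of compound 1 lie within the scatter of each other, so no order between them can be read. Compound 2 lies lower than compound 3, beyond the scatter.

Compound 4, `O=C1CC[C@@H](C(=O)N2CCC(NS(=O)(=O)c3cc(S(=O)(=O)c4ccccc4)ccc3C(F)(F)F)CC2)N1`, has not yet been measured. It differs from compound 3 in one place: hydrogen in place of tert-butoxycarbonyl on an amide-type nitrogen in a ring. Going by the values given here, the only measured step, a 4.7-fold lower number from compound 1 to compound 2 (0.67 log units; beyond the scatter), changes a group on the other side of the shared core, at the carbon bound to the carbonyl, and says nothing about the five-membered ring or its amide-type nitrogen. Among the compounds with values here, no measured pair reports what removing a tert-butoxycarbonyl from that nitrogen does.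

Within the data shown here, with no step bearing on this change, the expectation for compound 4 rests on compound 3 alone, and the step of no change at the digits printed from compound 3 to compound 4 (within the scatter) is expected to stay within the scatter, in no clear direction. Compound 4 is therefore estimated at 130 nM, with a range from 50 nM to 350 nM.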

Compound 4, half-maximal inhibitory concentration in the secreted frizzled-related protein 1 assay: 90 nM
For compound 4 the middle estimate is 1.4-fold (0.16 log units) above the measured one; the range from low to high includes it.
By their numbers in the secreted frizzled-related protein 1 assay, from the lowest: compound 2; then compounds 4, 3 and 1 (each within the scatter of the next).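

In the secreted frizzled-related protein 1 assay, taking tert-butoxycarbonyl off the amide-type nitrogen of the five-membered ring gives a 1.4-fold lower number from compound 3 to compound 4 (0.16 log units; within the scatter), so at this position the loss of that whole group produces no change that can be read. Compound 4 also places the bare 5-oxopyrrolidin-2-yl group alongside the two groups on the carbonyl carbon in the secreted frizzled-related protein 1 assay: the comparison with the piperazine-bearing compound shows a 1.6-fold lower number from compound 1 to compound 4 (0.19 log units; within the scatter), whereas the comparison with the imidazole-bearing compound shows a 3.0-fold higher number from compound 2 to compound 4 (0.48 log units; beyond the scatter), so only the (1H-imidazol-1-yl)methyl group keeps a lower number than 5-oxopyrrolidin-2-yl. In a physicochemical assay for solubility (a higher number here means a more soluble compound, a lower number a less soluble compound), compound 3 gives 50000 nM and compound 4 gives 100000 nM; the same removal gives a 2.0-fold higher number from compound 3 to compound 4 (0.30 log units; within the scatter), so this read-out does not separate the pair either.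

Nothing among the data accounts for any of these numbers. Among the compounds shown, only hydrogen and tert-butoxycarbonyl stand on that nitrogen, so it remains open whether a methyl, an acetyl or a longer chain there would move the number beyond the scatter.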